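Replacing a carbamoyl with a 2-hydroxyethyl on the pyrrolidine core

The source may report more compounds than this note shows. Statements on the series, on what has been measured and on what is new or still open speak of the compounds shown alone.

Of the compounds shown here, three sharing one core have been measured in an assay on the whole organism (plasma, strain Sprague-Dawley) for inhibition of Dipeptidyl peptidase 4 (Rattus norvegicus), with a stated time of 6 h, at a dose of 1 mg/kg by the oral route; a lower number here means less inhibition, a higher number more inhibition at the dose given (going by the name of the read-out). Compound 1 `C=CC[C@@H]1CN[C@H](C(=O)N2CCC[C@H]2C#N)C1` carries an allyl on a saturated ring carbon and gives 38%. Compound 2 `CCCNC(=O)[C@@H]1CN[C@H](C(=O)N2CCC[C@H]2C#N)C1` carries a propylcarbamoyl at the same place and gives 59%. Compound 3 `N#C[C@@H]1CCCN1C(=O)[C@@H]1C[C@H](C(N)=O)CN1` carries a carbamoyl there and gives 47%. Compound 3 thus stands second highest of the three numbers, though its gap to compound 1 lies within the scatter, while compound 2 sits above it beyond the scatter.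

The steps known so far are a number 21 percentage points higher from compound 1 to compound 2 (beyond the scatter), a number 9 percentage points higher from compound 1 to compound 3 (within the scatter) and a number 12 percentage points lower from compound 2 to compound 3 (beyond the scatter). Compound 4 `N#C[C@@H]1CCCN1C(=O)[C@@H]1C[C@H](CCO)CN1` differs from compound 3 by 2-hydroxyethyl in place of carbamoyl on a saturated ring carbon. Among the measured compounds shown here, no measured step introduces a 2-hydroxyethyl, so the nearest guide is the exchange of the allyl for the carbamoyl, where compound 1 and compound 3 differ only within the scatter. On that basis the change from compound 3 to compound 4 is expected to produce no step beyond the scatter in this assay, estimated as a number 2 percentage points lower from compound 3 to compound 4 (within the scatter). Compound 4 is therefore expected to give about 45%, with a range from 25% to 65%.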

Compound 4, a percentage reported as inhibition, in the whole organism at one dose (the size of the read-out at that dose, not a potency): 64%
Beside the measured number, compound 4's estimate is 19 percentage points below it; low and high end bracket the measured number.
By their numbers in this assay, from the lowest: compounds 1 and 3 (each within the scatter of the next); then compounds 2 and 4 (each within the scatter of the next).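

In this assay, the exchange on this saturated ring carbon is not neutral, even though the carbamoyl that leaves and the 2-hydroxyethyl that enters have the same count of heavy atoms, hydrogen-bond donors and hydrogen-bond acceptors: it gives a number 17 percentage points higher from compound 3 to compound 4 (beyond the scatter). The 2-hydroxyethyl gives a number 5 percentage points higher from compound 2 to compound 4 (within the scatter) in place of propylcarbamoyl, so these two groups cannot be told apart on this read-out, and a change at the end of the chain, hydroxymethyl in place of vinyl, gives a number 26 percentage points higher from compound 1 to compound 4 (beyond the scatter), which shows that a group without an amide can reach the upper level of this small series. Nothing measured on these compounds accounts for these steps.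

The compounds shown leave open whether the hydroxyl itself carries the step, a question that a shorter hydroxymethyl, a longer 3-hydroxypropyl, a 2-methoxyethyl or a 2-aminoethyl on the same carbon could address. On these data alone, the read-out in this assay also reflects a single dose and a single time, so how compound 2 and compound 4 would compare at other doses or times remains open.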